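The source may hold more compounds than are shown below. What is called first, only, known or untested is meant among the compounds shown, and "the series" means these compounds.

Measured compounds in a functional assay on Huh-7 cells (Homo sapiens) for antiproliferative activity, read by sulforhodamine B assay, with a stated time of 72 h; a lower number here means a stronger inhibitor, a higher number a weaker inhibitor:
Compound 1 `FC(F)(F)c1ccc(CN2CCN(Cc3cc(-c4ccc(OCc5ccccc5)cc4)on3)CC2)cc1`, which gives 1700 nM.
Compound 2 `Fc1ccccc1COc1ccc(-c2cc(CN3CCN(Cc4ccc(C(F)(F)F)cc4)CC3)no2)cc1`, which gives 1500 nM.

Compound 2 stands at the lower of the two numbers, but only by a 1.1-fold lower number from compound 1 to compound 2 (0.05 log units; within the scatter), a step that the data mark as within the scatter; so the two measured compounds are not separable on what is shown. Compound 3 `COc1cc(COc2ccc(-c3cc(CN4CCN(Cc5ccc(C(F)(F)F)cc5)CC4)no3)cc2)cc(OC)c1OC` is unmeasured in this assay. It differs from compound 2 by 3,4,5-trimethoxyphenyl in place of 2-fluorophenyl on a saturated chain carbon bound to an oxygen on an aromatic ring. Among the compounds with values here, the only measured step concerns a fluoro in place of hydrogen on an aromatic carbon and does not bear on a change of this kind; the data give no step that replaces one aryl group by another at this place. Compound 3 is therefore expected to land near compound 2, a change of no change at the digits printed from compound 2 to compound 3 (within the scatter), with a wide allowance in either direction because the data on compound 1 and compound 2 give only a 1.1-fold lower number from compound 1 to compound 2 (0.05 log units; within the scatter). The estimate for compound 3 is 1500 nM, expected to fall between 400 nM and 6000 nM.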

Compound 3, half-maximal inhibitory concentration: 500 nM
The estimate for compound 3 lay 3.0-fold (0.48 log units) above the measured number; the range from low to high includes it.
By their numbers in this assay, from the lowest: compound 3; then compounds 2 and 1 (each within the scatter of the next).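

In this assay there is a 3.0-fold lower number from compound 2 to compound 3 (0.48 log units; beyond the scatter) when 3,4,5-trimethoxyphenyl replaces 2-fluorophenyl, and a 3.4-fold lower number from compound 1 to compound 3 (0.53 log units; beyond the scatter) when it replaces phenyl on the same saturated chain carbon bound to an oxygen on an aromatic ring. Unlike the fluoro step, which stayed within the scatter, these changes of the whole aryl group show that the number responds to what sits at this place, though both steps are only modest. Nothing available accounts for this shift or links it to any property of the entering group.

The compounds shown leave open whether all three methoxy groups are needed, or whether a single methoxy group would give a similar step. They also leave open how an amine or a carboxylic acid on this aryl ring would compare.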